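Bromo for Chloro on the Pendant Aryl Ring

The source may hold more compounds than are shown below. What is called first, only, known or untested is meant among the compounds shown, and "the series" means these compounds.

Compound 1 `CCCCN(CC)c1cc(C)nc2c1NC(=O)CN2c1ccc(C)cc1Cl` is measured in an assay on HEK-293T cells for displacement of a labelled ligand from corticotropin-releasing factor receptor 1 (Homo sapiens), read by scintillation counting, with a stated time of 2 h (a lower number here means a stronger inhibitor, a higher number a weaker inhibitor), where compound 1 gives 4.4 nM. Among the two numbers in hand this is the higher, though only just: compound 2 `CCCCN(CC)c1cc(C)nc2c1NC(=O)CN2c1ccc(Br)cc1Cl` gives 2.7 nM, and the step of a 1.6-fold lower number from compound 1 to compound 2 (0.21 log units; within the scatter). That step exchanges a methyl for a bromo on the aromatic ring and so shows how a bromo may enter that ring without moving the number beyond the scatter.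

Compound 3 `CCCCN(CC)c1cc(C)nc2c1NC(=O)CN2c1ccc(C)cc1Br` has not yet been measured. It differs from compound 1 by bromo in place of chloro on an aromatic carbon. Within the data shown here, no measured pair changes a chloro for a bromo, so the only guide is the step from compound 1 to compound 2, which stayed within the scatter when a bromo entered the same ring. Compound 3 is therefore expected to show a step of a 1.1-fold lower number from compound 1 to compound 3 (0.04 log units; within the scatter) that lies inside the usual scatter in either direction. The estimate for compound 3 in this assay is 4 nM, with a range from 1.5 nM to 11 nM.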

Compound 3, inhibition constant: 4.4 nM
Estimate against measurement, compound 3: 1.1-fold (0.04 log units) below; measured number inside the range.
By their numbers in this assay, from the lowest: compounds 2, 1 and 3 (each within the scatter of the next).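

In this assay, the aromatic carbon ortho to a large group now has a direct reading of its own: 2-bromo-4-methylphenyl in place of 2-chloro-4-methylphenyl gives no change at the digits printed from compound 1 to compound 3 (within the scatter), so this position takes either halogen with no change that the assay can resolve. The earlier pair had changed only the group meta to this carbon, and the further comparison, a 1.6-fold higher number from compound 2 to compound 3 (0.21 log units; within the scatter), adds that 2-bromo-4-methylphenyl and 4-bromo-2-chlorophenyl also cannot be told apart, which means that all three compounds read alike whichever of these groups the ring carries. No independent evidence bears on why these exchanges leave the number in place, so the result stands as an observation alone.

The compounds shown carry only chloro, bromo and methyl on this ring, and since every step stays within the scatter, they mark no limit to what the position accepts. As far as these compounds go, how a methoxy group, an amine or a carboxylic acid on the same aromatic carbon would read remains open, as does the effect of a plain hydrogen there.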